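Nitro-Substituted Indole Sulfones: Amide Chain Variation and Cytotoxicity

The compounds below may be only part of what the source reports. "The series", "measured", "known", "first", "only" and "open" are said of these compounds alone.

Compound 1 `Cc1cc(C)cc(S(=O)(=O)c2c(C(=O)NCN3CCCCC3)[nH]c3ccc([N+](=O)[O-])cc23)c1`: 12000 nM
Compound 2 `Cc1cc(C)cc(S(=O)(=O)c2c(C(=O)NCCOc3ccccc3)[nH]c3ccc(Br)cc23)c1`: > 500000 nM
Compound 3 `Cc1cc(C)cc(S(=O)(=O)c2c(C(=O)NCc3ccccc3)[nH]c3ccc([N+](=O)[O-])cc23)c1`: 8000 nM

Of the compounds shown here, three have been measured in an ADME assay on CCRF-CEM cells (Homo sapiens) for cytotoxicity, read by cell counting; a higher number here means that more compound is tolerated, a lower number that less compound is tolerated. Compound 1 gives 12000 nM and compound 3 gives 8000 nM. For compound 2 only a limit was recorded, > 500000 nM. Among the measured compounds shown here, compound 3 thus holds the lowest of the two numbers, with compound 1 nearest, and the single step among them, a 1.5-fold lower number from compound 1 to compound 3 (0.18 log units; within the scatter), lies within the scatter.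

Compound 4 `Cc1cc(C)cc(S(=O)(=O)c2c(C(=O)NCCOc3ccccc3)[nH]c3ccc([N+](=O)[O-])cc23)c1` differs from compound 3 by phenoxymethyl in place of phenyl on a saturated chain carbon bound to an amide-type nitrogen. For the measured compounds named here, no measured step covers this change. Compound 2 carries the same 2-phenoxyethyl amide as compound 4 and reached the limit (the limit of > 500000 nM in this assay, at which 1 of the 3 values shown sits). Compound 4 is therefore expected to give 30000 nM, ranging from 8000 nM to 200000 nM. The expected step is a 3.8-fold higher number from compound 3 to compound 4 (0.57 log units; beyond the scatter).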

Compound 4, half-maximal cytotoxic concentration: > 500000 nM
Compound 4 ended at the assay's limit; the forecaster's own chance of this, stated with the estimate: 25%; at least 16-fold (1.22 log units) between middle value and limit.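

In this assay, with the nitro group kept, the amide chain now makes a large difference: an at least 62-fold higher number from compound 3 to compound 4 (1.79 log units; beyond the scatter), and an at least 41-fold higher number from compound 1 to compound 4 (1.61 log units; beyond the scatter). The earlier change on this carbon, a 1.5-fold lower number from compound 1 to compound 3 (0.18 log units; within the scatter), had stayed within the scatter. Compound 2 and compound 4 both stand at a limit, so the step from compound 2 to compound 4 cannot be read, and bromo and nitro cannot be told apart here: the limit of > 500000 nM in this assay, at which 2 of the 4 values shown sit.

As far as these compounds go, it remains open whether the chain length or the ether oxygen goes with the rise. A 2-phenylethyl amide, with no such oxygen, would separate the two.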